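Swapping the Aryl Ring for a Sulfonylpiperidine

The source may report more compounds than this note shows. Statements on the series, on what has been measured and on what is new or still open speak of the compounds shown alone.

Of the compounds shown here, two sharing one core have been measured in a functional assay on HCT-116 cells (Homo sapiens) for antiproliferative activity, read by sulforhodamine B assay, with a stated time of 72 h; on this read-out higher numbers stand for weaker inhibition and lower numbers for stronger inhibition. Compound 1 `COc1ncc(-c2ccc3ncc(NC(=O)C4CCCCC4)c(OC)c3c2)cc1NS(=O)(=O)c1ccc(F)cc1F` gives 4610 nM. Compound 2 `COc1ccc(CNc2cnc3ccc(-c4cnc(OC)c(NS(=O)(=O)c5ccc(F)cc5F)c4)cc3c2OC)cc1` gives 10200 nM. Among the compounds with values here, the single change between them, 4-methoxybenzyl in place of cyclohexylcarbonyl on a nitrogen on an aromatic ring, reads as a 2.2-fold higher number from compound 1 to compound 2 (0.34 log units; beyond the scatter). Within the data shown here, compound 2 thus stands at the higher, weaker end of the two numbers known so far.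

Compound 3 `COc1ncc(-c2ccc3ncc(NCC4CCN(S(C)(=O)=O)CC4)c(OC)c3c2)cc1NS(=O)(=O)c1ccc(F)cc1F` has not yet been measured. It differs from compound 2 at one spot: 1-(methylsulfonyl)piperidin-4-yl in place of 4-methoxyphenyl on a saturated chain carbon bound to a nitrogen on an aromatic ring. Among the measured compounds shown here, no measured step bears on this kind of exchange; the only step known alters the group on the ring nitrogen itself rather than the ring on the chain carbon, so it offers no direction. A modest step either way, or none beyond the scatter, seems possible, and a number near that of compound 2 is expected. The estimate for compound 3 is 8000 nM, with a range from 2500 nM to 25000 nM. This amounts to an expected step of a 1.3-fold lower number from compound 2 to compound 3 (0.11 log units; within the scatter).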

Compound 3, half-maximal inhibitory concentration: 1360 nM
Estimate against measurement, compound 3: 5.9-fold (0.77 log units) above; the measured number lies below the stated range.
By their numbers in this assay, from the lowest: compound 3; then compound 1; then compound 2.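

In this assay, the saturated chain carbon bound to a nitrogen on an aromatic ring proves sensitive to what it carries: 1-(methylsulfonyl)piperidin-4-yl in place of 4-methoxyphenyl gives a 7.5-fold lower number from compound 2 to compound 3 (0.88 log units; beyond the scatter), the largest step seen so far. The (1-(methylsulfonyl)piperidin-4-yl)methyl group in place of cyclohexylcarbonyl gives a 3.4-fold lower number from compound 1 to compound 3 (0.53 log units; beyond the scatter), so a carbonyl on that nitrogen is not required for the lowest number among these three compounds. No measurement shown here accounts for either step.

The exchange replaces an aromatic ring with a non-aromatic one and also brings in a methylsulfonyl group, and these two changes remain unseparated. Also open, on these data alone, is how the piperidine would fare with a free amine or an acetyl group on its nitrogen, or with a longer chain leading to it.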